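A few compounds are considered here, and "the series" means these few. Any claim that something is new, unique, unknown or untested is made for them only; others in the source may bear on it.

Compound 1, `COc1ccc(-c2nc(SCC(=O)c3sc(-c4ccc(Cl)cc4)nc3C)[nH]c(=O)c2C#N)cc1`: 88.3%
Compound 2, `COc1cccc(-c2nc(SCC(=O)c3sc(-c4ccc(Cl)cc4)nc3C)[nH]c(=O)c2C#N)c1`: 89.7%
Compound 3, `Cc1nc(-c2ccc(Cl)cc2)sc1C(=O)CSc1nc(-c2ccc(Cl)cc2)c(C#N)c(=O)[nH]1`: 98.4%

Among the measured compounds shown here, in a functional assay on U-87MG ATCC cells for antiproliferative activity against U-87 MG (Homo sapiens), read by MTT assay, with a stated time of 48 h, tested at 10 uM (a higher number here means a weaker effect of the compound at the concentration tested, a lower number a stronger effect), compound 3 gives the highest of the three numbers, but its gap to compound 2 lies within the scatter, and only the step of a number 10.1 percentage points higher from compound 1 to compound 3 (beyond the scatter) is beyond it, so compound 3 is not clearly the weakest. Compound 4, `Cc1nc(-c2ccc(Cl)cc2)sc1C(=O)CSc1nc(-c2cccc(Cl)c2)c(C#N)c(=O)[nH]1`, differs from compound 3 in one place: 3-chlorophenyl in place of 4-chlorophenyl on an aromatic carbon. For the measured compounds named here, the one measured step of the same kind, a 3-methoxyphenyl in place of a 4-methoxyphenyl, was a number 1.4 percentage points higher from compound 1 to compound 2 (within the scatter), within the scatter. The expected step is therefore a number 2.4 percentage points lower from compound 3 to compound 4 (within the scatter), no change beyond the scatter. Compound 4 is estimated at 96%, in the range 86% to 103%.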

Compound 4, a percentage reported as activity, at one concentration (the size of the read-out at that concentration, not a potency): 95.2%
For compound 4 the middle estimate is 0.8 percentage points above the measured one; measured number inside the range.
By their numbers in this assay, from the lowest: compounds 1, 2, 4 and 3 (each within the scatter of the next, the first and the last beyond it).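

In this assay, the change from 4-chlorophenyl to 3-chlorophenyl is a number 3.2 percentage points lower from compound 3 to compound 4 (within the scatter), so, as with the methoxy pair, moving the substituent around this phenyl ring shows no effect beyond the scatter. The change from 3-methoxyphenyl to 3-chlorophenyl is a number 5.5 percentage points higher from compound 2 to compound 4 (within the scatter), and that from 4-methoxyphenyl to 3-chlorophenyl is a number 6.9 percentage points higher from compound 1 to compound 4 (within the scatter), so neither clears the scatter. The earlier chloro-for-methoxy step is thus not clearly repeated, although the two steps also do not differ beyond the scatter: the same change on two cores in this assay, a number 10.1 percentage points higher (beyond the scatter) from compound 1 to compound 3 and a number 5.5 percentage points higher (within the scatter) from compound 2 to compound 4, 4.6 percentage points apart, within the scatter of two such steps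

All four compounds carry a methoxy or chloro phenyl at this position, tested at a single concentration. From the compounds shown here alone, what a phenyl ring bearing an amine or a carboxylic acid would do here stays open.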